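Imidazolyl against dimethylamino on the butynyl chain

This account rests on a few compounds, and the source may have more. Where it says the series, first, only, none or still open, it means among the compounds named here.

Compound 1 `CC(C#CCn1ccnc1)N1CCCC1=O` and compound 2 `CC(C#CCN(C)C)N1CCCC1=O` share one core; compound 3 `COC(=O)N(C)CC#CCn1ccnc1` and compound 4 `COC(=O)N(C)CC#CCN(C)C` share another, and the difference between the two cores is not broken down here. In a functional assay on the whole organism for agonist activity, with Mus musculus as the target (a higher number here means that more compound is needed for the effect, a lower number that less compound is needed), compound 1 gives only a limit, > 100 mg/kg. In this assay compound 2 gives 100 mg/kg. In this assay compound 3 gives 2 mg/kg, the lowest of the two numbers read, well beyond the scatter from compound 2. The step of a number no higher from compound 1 to compound 2 (the limit leaves the size open) is dimethylamino in place of 1H-imidazol-1-yl on a saturated chain carbon bound to a triple-bonded carbon; its size cannot be read because of the limit of > 100 mg/kg in this assay, at which 1 of the 3 values shown sits. The change planned for compound 4 is the same change, (dimethylamino in place of 1H-imidazol-1-yl on a saturated chain carbon bound to a triple-bonded carbon), at the same place. The step expected in this assay is a 1.3-fold lower number from compound 3 to compound 4 (0.12 log units; within the scatter). That expectation rests on the open direction of a number no higher from compound 1 to compound 2 (the limit leaves the size open) and on compound 3 already standing at 2 mg/kg, which leaves little room for a large drop in dose. Compound 4 is estimated in this assay at 1.5 mg/kg, with a likely span from 0.2 mg/kg to 15 mg/kg.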

Compound 4, dose for half-maximal effect: 17.3 mg/kg
The estimate for compound 4 lay 12-fold (1.06 log units) below the measured number; measured number outside the range, above it.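

In this assay, dimethylamino in place of 1H-imidazol-1-yl on the core of compound 3 gives an 8.7-fold higher number from compound 3 to compound 4 (0.94 log units; beyond the scatter), so on this core the change raises the dose needed. The same change does not carry over as one fixed step from one core to the other: the same change on two cores in this assay, a number no higher (the limit leaves the size open) from compound 1 to compound 2 and an 8.7-fold higher number (0.94 log units; beyond the scatter) from compound 3 to compound 4, at least 8.6-fold (0.93 log units) apart, beyond the scatter of two such steps

Compound 1 gives only a limit, > 100 mg/kg, so the step on its core cannot be read, and the pair shows neither the true size of the gap between the two steps nor any rule beyond these two cores: the limit of > 100 mg/kg in this assay, at which 1 of the 4 values shown sits.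

The compounds shown leave open how pyrrolidin-1-yl or 1H-pyrazol-1-yl would behave on a saturated chain carbon bound to a triple-bonded carbon, on either core. They also leave open whether a third core would follow the step seen from compound 3 to compound 4 or the one seen on the core of compound 1.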